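The source may report more compounds than this note shows. Statements on the series, on what has been measured and on what is new or still open speak of the compounds shown alone.

Measured so far:
compound 1 `O=C(OCc1ccccc1)SCCCCCCNC(=O)c1cc(-c2ccncc2)n[nH]1` — 15400 nM
compound 2 `CC(=O)SCCCCCCNC(=O)c1cc(-c2ccncc2)n[nH]1` — 36000 nM

In a functional assay on PC-3 cells (Homo sapiens) for inhibition, read by MTT assay, with a stated time of 96 h (a higher number here means a weaker inhibitor of growth, a lower number a stronger inhibitor of growth), compound 2 gives the highest of the two numbers; its nearest neighbour is compound 1, which lies a 2.3-fold higher number from compound 1 to compound 2 (0.37 log units; beyond the scatter) away. Compound 3 `CSCCCCCCNC(=O)c1cc(-c2ccncc2)n[nH]1` is the next step from compound 2: methyl in place of acetyl on a sulfur. Among the measured compounds shown here, no measured step touches the sulfur itself; the only comparable trimming of the group on the carbonyl side, a 2.3-fold higher number from compound 1 to compound 2 (0.37 log units; beyond the scatter), raised the number modestly. For the measured compounds named here, removing the carbonyl altogether has no precedent here, so the direction is uncertain; a small further rise in this assay is expected, a 1.3-fold higher number from compound 2 to compound 3 (0.10 log units; within the scatter). Compound 3 is estimated at 45000 nM (range 18000 nM to 110000 nM).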

Compound 3, concentration for 50% growth inhibition: > 50000 nM
Compound 3: only a limit was reported; the forecaster's own chance of this, stated with the estimate: 20%; at least 1.1-fold (0.04 log units) between middle value and limit.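

Compound 3 gives a limit and not a number (> 50000 nM). Methyl in place of acetyl on the sulfur removes the carbonyl, but its step (an at least 1.3-fold higher number from compound 2 to compound 3 (0.14 log units; that floor lies within the scatter)) has a floor within the scatter, so compound 3 is not separated from compound 2. Methyl in place of benzyloxycarbonyl on the same sulfur is resolved (an at least 3.2-fold higher number from compound 1 to compound 3 (0.51 log units; beyond the scatter)), so growth inhibition falls when the whole group is replaced.

Still open, on these data alone, is the true size of the step from acetyl to methyl. Also open, as far as these compounds go, is how a free thiol, an amine or a carboxylic acid in this place would read.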